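The compounds below may be only part of what the source reports. "The series", "measured", "known", "first", "only" and "open" are said of these compounds alone.

Three compounds built on one shared core have been run through a toxicity assay on Huh-7.5 cells (Homo sapiens) for inhibition, read by MTT assay, with a stated time of 96 h; on this read-out higher numbers stand for lower toxicity in this test and lower numbers for higher toxicity in this test. Compound 1 `CN1CCN(Cc2ccc(NC(=O)c3ccc(OCCCCl)c(N)c3)cc2C(F)(F)F)CC1` gives 12900 nM. Compound 2 `CC1CN(Cc2ccc(NC(=O)c3ccc(OCCCCl)c([N+](=O)[O-])c3)cc2C(F)(F)F)CC(C)O1` gives 2300 nM, and compound 3 `CN1CCN(Cc2ccc(NC(=O)c3ccc(OCCCCl)c(F)c3)cc2C(F)(F)F)CC1` gives 8800 nM. The only single-point step among these is a 1.5-fold lower number from compound 1 to compound 3 (0.17 log units; within the scatter), so swapping an amino group for a fluorine did not move the number beyond the scatter. On these three numbers compound 3 holds the second highest place: compound 1 sits nearest, within the scatter of it, while compound 2 lies furthest, with a gap beyond the scatter.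

Compound 4 `CN1CCN(Cc2ccc(NC(=O)c3ccc(OCCCCl)c([N+](=O)[O-])c3)cc2C(F)(F)F)CC1` is the next compound; its change from compound 3 is nitro in place of fluoro on an aromatic carbon. Going by the values given here, no measured step matches this exact swap. The step from compound 1 to compound 3 touches the same spot on the core but a different group and was within the scatter, so it gives no direction. Compound 2 also carries a nitro group on its core, and its number is the lowest of the three, though its other end differs from that of compound 3, so the two are not a clean pair. A lower number is therefore expected for compound 4, a step of a 2.2-fold lower number from compound 3 to compound 4 (0.34 log units; beyond the scatter). The estimate for compound 4 in this assay is 4000 nM, with a range from 1800 nM to 10000 nM.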

Compound 4, half-maximal cytotoxic concentration: 6800 nM
Compound 4: middle estimate off by 1.7-fold (0.23 log units), on the low side, within the range that was stated.
By their numbers in this assay, from the lowest: compound 2; then compounds 4, 3 and 1 (each within the scatter of the next).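

Measured in this assay, the swap gives a 1.3-fold lower number from compound 3 to compound 4 (0.11 log units; within the scatter), and the comparison with the amino compound gives a 1.9-fold lower number from compound 1 to compound 4 (0.28 log units; within the scatter), so amino, fluoro and nitro on this aromatic carbon, ortho to the 3-chloropropoxy group, cannot be told apart here even though nitro is the larger group, with 3 heavy atoms against 1 for fluoro. Going by these compounds alone, the new compound also gives the first clean look at the other end of the molecule: with nitro held constant, 4-methylpiperazin-1-yl in place of 2,6-dimethylmorpholin-4-yl gives a 3.0-fold higher number from compound 2 to compound 4 (0.47 log units; beyond the scatter), a modest step beyond the scatter, which ties the low number of compound 2 to that end rather than to its nitro group. Nothing measured here explains either result.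

From the compounds shown here alone, whether a nitrile or a carboxylic acid on this same carbon would also stay within the scatter remains open, as does the outcome of a longer chain in place of the 3-chloropropoxy group. The change at the other end rests on a single pair, so it is also unknown whether it would hold with amino or fluoro on the aromatic carbon.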